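A few compounds are considered here, and "the series" means these few. Any claim that something is new, unique, unknown or untested is made for them only; others in the source may bear on it.

Compound 1 `COc1cc(OCc2cccc(-c3ccc(C#N)cn3)c2)c2cc(-c3cn4nc(OC)sc4n3)oc2c1` gives 1.57 h
Compound 2 `CNC(=O)c1ccc(-c2nc(COc3cc(OC)cc4oc(-c5cn6nc(OC)sc6n5)cc34)cs2)cc1` gives 0.983 h

In an ADME assay on microsomes from liver (Homo sapiens) for metabolic stability (a lower number here means that the compound disappears faster, a higher number that the compound lasts longer), compound 1 and compound 2 cannot be told apart, since their values lie within the usual scatter of each other. Compound 3 `COc1cc(OCc2cccc(-c3cncnc3)c2)c2cc(-c3cn4nc(OC)sc4n3)oc2c1` keeps the core of compound 1 but carries pyrimidin-5-yl in place of 5-cyanopyridin-2-yl on an aromatic carbon. Among the compounds with values here, no measured pair shows what this swap does, so no shift beyond the scatter is expected in this assay here. The estimated step of a 1.3-fold lower number from compound 1 to compound 3 (0.12 log units; within the scatter) stays within that scatter. For compound 3 the estimated half-life is 1.2 h with an expected range of 0.6 h to 2.4 h in this measurement.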

Compound 3, half-life: 0.117 h
Compound 3: the middle estimate sits 10-fold (1.01 log units) above what was measured; measured number outside the range, below it.
By their numbers in this assay, from the lowest: compound 3; then compounds 2 and 1 (each within the scatter of the next).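

Replacing 5-cyanopyridin-2-yl with pyrimidin-5-yl on this aromatic carbon brings a 13-fold lower number from compound 1 to compound 3 (1.13 log units; beyond the scatter) in this assay and so shows that the group at this place, meta to a large group, strongly affects how long the compound lasts. Nothing available explains why this swap has so large an effect. The compounds shown leave open which part of the change matters, the nitrile or the ring itself. A plain pyridin-2-yl group without the nitrile, or a pyrimidine ring carrying a nitrile, at the same place would separate the two.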